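The source may report more compounds than this note shows. Statements on the series, on what has been measured and on what is new or still open speak of the compounds shown alone.

Measured in an ADME assay on NIH3T3 cells (Mus musculus) for cytotoxicity; on this read-out lower numbers stand for an effect already at smaller amounts and higher numbers for an effect only at larger amounts of compound:
Compound 1 `Cc1cc(Oc2cccc(Cn3cccn3)c2)cc(C)c1Cl`: > 100000 nM, a limit.
Compound 2 `Cc1cc(Oc2cccc(Cn3nccn3)c2)cc(C)c1Cl`: > 100000 nM, a limit.
Compound 3 `Cc1cc(Oc2cccc(Cn3cnnc3)c2)cc(C)c1Cl`: > 100000 nM, a limit.

Compound 3 has no number and sits at the limit of > 100000 nM in this assay, at which 3 of the 3 values shown sit. Compound 4 `Cc1nnc(-c2cccc(Oc3cc(C)c(Cl)c(C)c3)c2)o1` differs from it by 5-methyl-1,3,4-oxadiazol-2-yl in place of (4H-1,2,4-triazol-4-yl)methyl on an aromatic carbon. The nearest measured changes swap one ring for another on a saturated chain carbon bound to an aromatic carbon: a step that the two limits leave unreadable from compound 1 to compound 2, a step that the two limits leave unreadable from compound 1 to compound 3 and a step that the two limits leave unreadable from compound 2 to compound 3. None has a readable size, so they give only weak guidance. Resting on a step that the two limits leave unreadable from compound 2 to compound 3 for compound 3, no shift in either direction is expected in this assay, and the expected step is a number no higher from compound 3 to compound 4 (the limit leaves the size open). Compound 4 is estimated at 100000 nM, with an expected range from 40000 nM to 200000 nM.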

Compound 4, half-maximal effective concentration: 46100 nM
Beside the measured number, compound 4's estimate is 2.2-fold (0.34 log units) above it; the measured number falls inside the stated range.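

In this assay, compound 4 alone of the four compounds shown gives a number rather than a limit, so a change at this aromatic carbon can bring the read-out within measurable range: the limit of > 100000 nM in this assay, at which 3 of the 4 values shown sit. The 5-methyl-1,3,4-oxadiazol-2-yl group gives an at least 2.1-fold lower number from compound 3 to compound 4 (0.33 log units; beyond the scatter), and likewise an at least 2.1-fold lower number from compound 2 to compound 4 (0.33 log units; beyond the scatter) and an at least 2.1-fold lower number from compound 1 to compound 4 (0.33 log units; beyond the scatter). Going by these compounds, the true sizes of these steps stay open, since each starts from a limit.

Ring and saturated chain carbon change together, so the compounds shown do not separate their contributions. On these data alone, how an amine or a carboxylic acid on this aromatic carbon would read also remains open.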